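The source may hold more compounds than are shown below. What is called first, only, known or untested is meant among the compounds shown, and "the series" means these compounds.

Measured compounds in a functional assay on U-251 cells (Homo sapiens) for inhibition, read by MTT assay, with a stated time of 2 days; a higher number here means that more compound is tolerated, a lower number that less compound is tolerated:

compound 1 `COc1ccc(NC(=O)CNCCCC(=O)Nc2ccccc2N)cc1` gives > 100000 nM, a limit of the assay.
compound 2 `Cc1ccc(NC(=O)CNc2ccc(C(=O)Nc3ccccc3N)cc2)cc1` gives > 100000 nM, a limit of the assay.
compound 3 `Nc1ccccc1NC(=O)CCCNCC(=O)Nc1ccc(Cl)cc1` gives > 100000 nM, a limit of the assay.

Compound 1 stands at the limit of this assay, with no number of its own. Compound 2 and compound 3 stand at the same limit, so no order among the three can be read; the point on the scale is the limit of > 100000 nM in this assay, at which 3 of the 3 values shown sit.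

The step to compound 4 `Nc1ccccc1NC(=O)CCCNCC(=O)Nc1cccc(Cl)c1` changes compound 1 as follows: 3-chlorophenyl in place of 4-methoxyphenyl on an amide-type nitrogen

For the measured compounds named here, the only measured step that touches the same place is a step that the two limits leave unreadable from compound 1 to compound 3; since both ends of it are limits, its size cannot be read. Going by the values given here, no measured compound differs from compound 1 by 3-chlorophenyl in place of 4-methoxyphenyl, so no step of exactly this kind is on record.

With all three measured values sitting at the limit, compound 4 is expected to remain at the limit as well, and the measurement will most likely again report only a limit. The expected step is a step that the limit leaves unreadable from compound 1 to compound 4, that is none beyond the scatter. Compound 4 is therefore estimated at 150000 nM, within a range from 50000 nM to 500000 nM.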

Compound 4, concentration lethal to 50% of the cells: > 100000 nM
Compound 4: a limit, no number (the forecaster's own chance of this, stated with the estimate: 80%); the middle value is on the limit's open side.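

In this assay compound 4 gives > 100000 nM as a limit of the assay, not a number. Its steps from compound 1 and from compound 3 cannot be read, since both ends of each are limits. The compounds shown leave open whether this assay can yield a readable value for any compound of this series.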